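Series notes: aromatic ether change with a basic acrylamide

The source may report more compounds than this note shows. Statements on the series, on what has been measured and on what is new or still open speak of the compounds shown alone.

Measured so far:
compound 1 `CC(C)=CC(=O)Nc1cc2c(N3CCc4ccccc43)ncnc2cc1O[C@@H]1CCOC1` – 4620 nM
compound 2 `COc1cc2ncnc(N3CCc4ccccc43)c2cc1NC(=O)/C=C/CN1CCC(CO)CC1` – 2650 nM

In a functional assay on PC-3 cells (Homo sapiens) for antiproliferative activity, read by MTT assay, with a stated time of 72 h (a higher number here means a weaker inhibitor, a lower number a stronger inhibitor), compound 2 gives the lower of the two numbers shown, with compound 1 within the usual scatter of it, so no order between the two is claimed. Among the measured compounds shown here, no step between the measured compounds is known. Compound 3 `O=C(/C=C/CN1CCC(CO)CC1)Nc1cc2c(N3CCc4ccccc43)ncnc2cc1O[C@@H]1CCOC1` differs from compound 2 in one place: oxolan-3-yl in place of methyl on an oxygen on an aromatic ring. Compound 1 already carries this ether on the same core, and its value in this assay sits close to that of compound 2. On that basis the expected step of a 1.0-fold lower number from compound 2 to compound 3 (0.01 log units; within the scatter) is none beyond the scatter. Compound 3 is therefore estimated at 2600 nM in this assay, within 1000 nM to 7000 nM.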

Compound 3, half-maximal inhibitory concentration: 3310 nM
Beside the measured number, compound 3's estimate is 1.3-fold (0.10 log units) below it; low and high end bracket the measured number.
By their numbers in this assay, from the lowest: compounds 2, 3 and 1 (each within the scatter of the next).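

In this assay, oxolan-3-yl in place of methyl on the oxygen, with the 4-(hydroxymethyl)piperidin-1-yl side chain kept, gives a 1.2-fold higher number from compound 2 to compound 3 (0.10 log units; within the scatter) and so does not separate the pair. With the ether kept, the change on the carbonyl carbon gives a 1.4-fold lower number from compound 1 to compound 3 (0.14 log units; within the scatter) and also stays unresolved. No measured evidence bears on either step.

Open, going by these compounds, is whether a longer chain ending in an amine on that oxygen would give a step beyond the scatter. On these data alone, a carboxylic acid on the piperidine in place of hydroxymethyl is also open.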